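Sulfonyl aryl swap carried from one core to another

A few compounds are considered here, and "the series" means these few. Any claim that something is new, unique, unknown or untested is made for them only; others in the source may bear on it.

Measured so far in a functional assay on HL-60 cells (Homo sapiens) for cytotoxicity, read by luminescence; a higher number here means a weaker inhibitor, a lower number a stronger inhibitor:

compound 1, `C=C(CC)C(=O)c1ccc(OCC(=O)N2CCN(S(=O)(=O)c3ccc([N+](=O)[O-])cc3)CC2)c(Cl)c1Cl`: compound 1 gives 3260 nM
compound 2, `C=C(CC)C(=O)c1ccc(OCC(=O)N2CCN(S(=O)(=O)c3cccc4cccnc34)CC2)c(Cl)c1Cl`: compound 2 gives 2980 nM
compound 3, `C=C(CC)C(=O)c1ccc(OCC(=O)NC2CCN(S(=O)(=O)c3ccc([N+](=O)[O-])cc3)CC2)c(Cl)c1Cl`: compound 3 gives 2470 nM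

Compound 1 and compound 2 share a core and differ in one place, (quinolin-8-yl in place of 4-nitrophenyl on a sulfonyl sulfur). That swap gave a 1.1-fold lower number from compound 1 to compound 2 (0.04 log units; within the scatter), so within this pair the change left the read-out essentially unmoved. Compound 3 sits on a second core; the difference between the two cores is not broken down here. Its value lies close to both of the first two, and none of the three numbers is separated from the others by more than the usual scatter, so no order can be read among them.

Compound 4, `C=C(CC)C(=O)c1ccc(OCC(=O)NC2CCN(S(=O)(=O)c3cccc4cccnc34)CC2)c(Cl)c1Cl`, is not yet measured. It relates to compound 3 as compound 2 relates to compound 1: quinolin-8-yl in place of 4-nitrophenyl on a sulfonyl sulfur. The place line is the same word for word in both pairs, so this is the same change, seen now for the second time among these compounds.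

Among the measured compounds shown here, the only evidence for the size of the step is the earlier pair, where the change was within the scatter. Compound 4 is therefore expected to land near compound 3, with an estimated step of a 1.1-fold lower number from compound 3 to compound 4 (0.03 log units; within the scatter), resting on the flat result of a 1.1-fold lower number from compound 1 to compound 2 (0.04 log units; within the scatter) and on the starting point that compound 3 gives 2470 nM. The estimate for compound 4 in this assay is 2300 nM, with a range from 1200 nM to 4500 nM, the width reflecting that a single prior pair is a thin basis for transfer between cores.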

Compound 4, half-maximal inhibitory concentration: 970 nM
Estimate against measurement, compound 4: 2.4-fold (0.37 log units) above, outside the stated range (below it).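

In this assay, quinolin-8-yl in place of 4-nitrophenyl on the sulfonyl sulfur gives a 2.5-fold lower number from compound 3 to compound 4 (0.41 log units; beyond the scatter) on the second core, a modest step, whereas the same change on the first core gave a 1.1-fold lower number from compound 1 to compound 2 (0.04 log units; within the scatter) and left the read-out essentially unmoved. Read singly, the two steps might suggest that the change pays off on only one core, but set side by side they cannot be told apart: the same change on two cores in this assay, a 1.1-fold lower number (0.04 log units; within the scatter) from compound 1 to compound 2 and a 2.5-fold lower number (0.41 log units; beyond the scatter) from compound 3 to compound 4, 2.3-fold (0.37 log units) apart, within the scatter of two such steps. The series therefore fits a single modest effect of this change on both cores, as well as an effect that depends on the core, and two pairs in one assay can neither establish transfer nor show that it fails, nor fix the size of the step.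

The compounds shown leave open how a plain phenyl or a naphthalen-1-yl on the sulfonyl sulfur would compare with quinolin-8-yl on either core, and so whether the ring nitrogen of that group has any part in the step. On these data alone, it also stays open whether a further pair on a third core, or a repeat of these two pairs, would separate the steps or bring them together.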